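This account rests on a few compounds, and the source may have more. Where it says the series, first, only, none or still open, it means among the compounds named here.

Compound 1 `C[C@H](Nc1ncnc2[nH]cnc12)c1nn(-c2cccnc2)c2cc(F)ccc12` is one of three analogues that share a core and differ only on a saturated chain carbon. In a functional assay on HepG2 cells (Homo sapiens) for inhibition, read by sulforhodamine B assay, with a stated time of 72 h (on this read-out lower numbers stand for stronger inhibition and higher numbers for weaker inhibition), compound 1 gives 37500 nM, the highest of the two numbers shown. Compound 2 `CC[C@H](Nc1ncnc2[nH]cnc12)c1nn(-c2cccnc2)c2cc(F)ccc12` gives 33900 nM in this assay, a step of a 1.1-fold lower number from compound 1 to compound 2 (0.04 log units; within the scatter) that stays within the scatter. Compound 3 `CC(C)[C@H](Nc1ncnc2[nH]cnc12)c1nn(-c2cccnc2)c2cc(F)ccc12` reaches only a limit in this assay, > 40000 nM (the limit of > 40000 nM in this assay, at which 1 of the 3 values shown sits). Compound 4 `C[C@H](Nc1ncnc2[nH]cnc12)c1nn(-c2ccccn2)c2cc(F)ccc12` differs from compound 1 at another site: pyridin-2-yl in place of pyridin-3-yl on an aromatic nitrogen. For the measured compounds named here, no measured step touches this site, and the steps that were measured, a 1.1-fold lower number from compound 1 to compound 2 (0.04 log units; within the scatter) and an at least 1.1-fold higher number from compound 2 to compound 3 (0.07 log units; that floor lies within the scatter), all stayed within the scatter, so no step beyond the scatter is expected. Compound 4 is therefore expected at 37000 nM, within 15000 nM to 80000 nM. The expected step is a 1.0-fold lower number from compound 1 to compound 4 (0.01 log units; within the scatter).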

Compound 4, half-maximal inhibitory concentration: 29900 nM
Estimate against measurement, compound 4: 1.2-fold (0.09 log units) above, within the range that was stated.
By their numbers in this assay, from the lowest: compounds 4, 2 and 1 (each within the scatter of the next). At a limit, above all of these: compound 3.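

In this assay, for the compounds shown here, the swap of pyridin-2-yl for pyridin-3-yl on an aromatic nitrogen gives a 1.3-fold lower number from compound 1 to compound 4 (0.10 log units; within the scatter) at a site the earlier steps did not touch. This position therefore tolerates the exchange of one pyridine attachment for the other, which keeps the same atoms and counts, with no change beyond the scatter. Nothing shown here gives a cause for this step. Going by these compounds, what stays open is how a phenyl ring, a pyridin-4-yl group or an aminopyridine on this aromatic nitrogen would read, and whether any group here would move the number beyond the scatter.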